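Aminoethyl amide of the piperidine acid in the stilbene series

A few compounds are considered here, and "the series" means these few. Any claim that something is new, unique, unknown or untested is made for them only; others in the source may bear on it.

Compound 1 `COc1ccc(/C=C\c2cc(OC)c(OC)c(OC)c2)cc1OCc1ccc(CN2CCCC[C@H]2C(=O)O)cc1` is one of three analogues of the shared core measured in an ADME assay on NCM460 cells (Homo sapiens) for cytotoxicity, read by CCK-8 assay, with a stated time of 48 h; on this read-out lower numbers stand for stronger inhibition and higher numbers for weaker inhibition. In this assay compound 1 gives a value that is a limit of the assay, > 50000 nM. Compound 2 `COc1ccc(/C=C\c2cc(OC)c(OC)c(OC)c2)cc1OCc1ccc(CN2CC[C@H](C(=O)O)C2)cc1` likewise gives only a limit of the assay in this assay, > 50000 nM. Among the measured compounds shown here, compound 3 `COc1ccc(/C=C\c2cc(OC)c(OC)c(OC)c2)cc1OCc1ccc(CNCCNC(C)=O)cc1` is the one analogue with a number in this assay, 54000 nM. Accordingly the steps a step that the two limits leave unreadable from compound 1 to compound 2, a step that the limit leaves unreadable from compound 1 to compound 3 and a step that the limit leaves unreadable from compound 2 to compound 3 cannot be sized; they show only that all three compounds sit at or near (the limit of > 50000 nM in this assay, at which 2 of the 3 values shown sit), with weak cytotoxicity throughout.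

Compound 4 `COc1ccc(/C=C\c2cc(OC)c(OC)c(OC)c2)cc1OCc1ccc(CN2CCCCC2C(=O)NCCN)cc1` is not yet measured. It differs from compound 1 as follows: 2-((2-aminoethyl)carbamoyl)piperidin-1-yl in place of 2-carboxypiperidin-1-yl on a saturated chain carbon bound to an aromatic carbon. For the measured compounds named here, none of the measured steps changes this part of the molecule in the same way, and the two steps that leave compound 1 cannot be read, so no step of a readable size in this assay bears on the change. The expectation is therefore no step beyond the scatter, with a fair chance that the assay again reports only a limit, such that compound 4 is expected at 50000 nM (range 20000 nM to 150000 nM), the estimated step being a number no higher from compound 1 to compound 4 (the limit leaves the size open).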

Compound 4, half-maximal inhibitory concentration: > 50000 nM
Compound 4: no number, only a limit (the forecaster's own chance of this, stated with the estimate: 55%); the middle value lies on the limit itself.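

In this assay compound 4 gives > 50000 nM, which is a limit of the assay. The steps to compound 4 from compound 1, compound 2 and compound 3 therefore cannot be read, and the series stays at the top of the range: the limit of > 50000 nM in this assay, at which 3 of the 4 values shown sit.

The compounds shown leave open what size of change, if any, 2-((2-aminoethyl)carbamoyl)piperidin-1-yl brings in place of 2-carboxypiperidin-1-yl in this assay.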